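Exchanging the Ring Amine in Compound 2 for (3-Chlorophenyl)amino

The source may report more compounds than this note shows. Statements on the series, on what has been measured and on what is new or still open speak of the compounds shown alone.

Measured so far:
compound 1 `Nc1ccccc1NC(=O)c1ccc(Cn2cnc3c(NCc4ccccc4)nc(Cl)nc32)cc1`: 68.3%
compound 2 `CC1CCN(c2nc(Cl)nc3c2ncn3Cc2ccc(C(=O)Nc3ccccc3N)cc2)CC1`: 70.9%

In a functional assay on HCT-116 cells (Homo sapiens) for antiproliferative activity, read by CCK-8 assay, with a stated time of 72 h, tested at 2 uM (a lower number here means a weaker effect, a higher number a stronger effect of the compound at the concentration tested), compound 1 gives 68.3%, and compound 2 gives 70.9%. Compound 2 carries the higher of the two numbers, yet the step of a number 2.6 percentage points higher from compound 1 to compound 2 (within the scatter) lies within the scatter, so the two are not separated. Compound 3 `Nc1ccccc1NC(=O)c1ccc(Cn2cnc3c(Nc4cccc(Cl)c4)nc(Cl)nc32)cc1` is the next member: (3-chlorophenyl)amino in place of 4-methylpiperidin-1-yl on an aromatic carbon. For the measured compounds named here, the only measured step touches the same position with a different group and stayed within the scatter; no measured step covers an aromatic amine entering there. Compound 3 is therefore expected to move by a number 5.9 percentage points lower from compound 2 to compound 3 (within the scatter), with an estimate of 65% between 45% and 85%.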

Compound 3, a percentage reported as inhibition, at one concentration (the size of the read-out at that concentration, not a potency): 56.2%
The estimate for compound 3 lay 8.8 percentage points above the measured number; measured number inside the range.
By their numbers in this assay, from the lowest: compound 3; then compounds 1 and 2 (each within the scatter of the next).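

At this position of the shared core, the exchange now registers in this assay: (3-chlorophenyl)amino in place of 4-methylpiperidin-1-yl gives a number 14.7 percentage points lower from compound 2 to compound 3 (beyond the scatter), whereas the earlier exchange of benzylamino for 4-methylpiperidin-1-yl stayed within the scatter. On the same nitrogen, 3-chlorophenyl in place of benzyl gives a number 12.1 percentage points lower from compound 1 to compound 3 (beyond the scatter), so both neighbouring compounds stand apart from compound 3 by a modest step. Nothing here explains this drop. On these data alone, whether it follows the chloro group or the aromatic ring on the amine remains open, and phenylamino without chlorine would separate the two. As far as these compounds go, how a morpholin-4-yl ring would behave at this position is also open.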